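Carboxymethyl to Carbamoyl: Expected Drop in Maximal Response

This account rests on a few compounds, and the source may have more. Where it says the series, first, only, none or still open, it means among the compounds named here.

Compound 1 `Cc1nc(-c2ccc(C(F)(F)F)cc2)sc1CNc1ccc(CCCC(=O)O)cc1` is the lower of the two measured entries in a functional assay on CHO cells for agonist activity at Free fatty acid receptor 1 (Homo sapiens), read by a luciferase reporter; on this read-out higher numbers stand for larger maximal responses and lower numbers for smaller maximal responses: compound 1 gives 44%, while compound 2 `O=C(O)COc1ccc(NCc2cccc(Oc3ccccc3)c2)cc1` gives 84%, a gap beyond the usual scatter. Compound 3 `Cc1nc(-c2ccc(C(F)(F)F)cc2)sc1CNc1ccc(CCC(N)=O)cc1` keeps the core of compound 1 and differs only at the chain end: carbamoyl in place of carboxymethyl on a saturated chain carbon, two bonds along the chain from an aromatic carbon. Going by the values given here, no measured pair shares this change, so the expectation rests on the change alone. A downward step beyond the scatter is expected, namely a number 29 percentage points lower from compound 1 to compound 3 (beyond the scatter). For compound 3 the maximal response is estimated at 15%, with a range from 0% to 45%.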

Compound 3, largest response reached (reported as percent of maximum), in percent of the reference or control that the assay uses: 88%
Compound 3: middle estimate off by 73 percentage points, on the low side, and the stated range ends below it.
By their numbers in this assay, from the lowest: compound 1; then compounds 2 and 3 (each within the scatter of the next).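

In this assay, going by these compounds alone, carbamoyl in place of carboxymethyl on a saturated chain carbon, two bonds along the chain from an aromatic carbon, gives a number 44 percentage points higher from compound 1 to compound 3 (beyond the scatter), the first step read from a single change. On the core of compound 1, a large maximal response therefore does not depend on the carboxymethyl end. No measurement at hand accounts for the size of this step.

As far as these compounds go, whether the step carries over to another core remains open. So does how a nitrile, a methyl ester or a longer chain ending in carbamoyl would read at this place in this assay.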